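Removing the ring-nitrogen methyl from compound 1

This account rests on a few compounds, and the source may have more. Where it says the series, first, only, none or still open, it means among the compounds named here.

In a functional assay on HepG2 cells (Homo sapiens) for cytotoxicity, read by MTT assay, with a stated time of 24 h (on this read-out higher numbers stand for weaker inhibition and lower numbers for stronger inhibition), compound 1 `CN1C/C(=C\c2cccnc2)C(=O)/C(=C/c2ccccc2F)C1` gives 4810 nM and compound 2 `CN1C/C(=C\c2ccncc2)C(=O)/C(=C/c2ccccc2F)C1` gives 4600 nM, so the two sit level within the scatter. Compound 3 `O=C1/C(=C/c2cccnc2)CNC/C1=C\c1ccccc1F` is still unmeasured. It differs from compound 1 as follows: hydrogen in place of methyl on an amine nitrogen in a ring. Going by the values given here, the sole measured step, a 1.0-fold lower number from compound 1 to compound 2 (0.02 log units; within the scatter), concerns pyridin-4-yl in place of pyridin-3-yl, and no measured step touches the amine nitrogen, so guidance is weak. The expected step is a 1.2-fold lower number from compound 1 to compound 3 (0.08 log units; within the scatter), which is no change beyond the scatter. The estimated value for compound 3 is 4000 nM, with an expected range of 1500 nM to 10000 nM.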

Compound 3, half-maximal inhibitory concentration: 21000 nM
Beside the measured number, compound 3's estimate is 5.3-fold (0.72 log units) below it, and the stated range ends below it.
By their numbers in this assay, from the lowest: compounds 2 and 1 (each within the scatter of the next); then compound 3.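

In this assay, hydrogen in place of methyl on an amine nitrogen in a ring gives a 4.4-fold higher number from compound 1 to compound 3 (0.64 log units; beyond the scatter) and so moves the number beyond the scatter, which the change from pyridin-3-yl to pyridin-4-yl between compound 1 and compound 2 did not do. At this position the methyl goes with the stronger inhibition, though this rests on a single pair carrying pyridin-3-yl. No available measurement bears on the reason for this step.

From the compounds shown here alone, whether the step carries over to the pyridin-4-yl compound 2 stays open. So does how an ethyl group or an acetyl group on that nitrogen would compare with methyl and hydrogen.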